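Carboxy-fluorophenoxy variant of a sphingosine 1-phosphate receptor 2 antagonist

The compounds below may be only part of what the source reports. "The series", "measured", "known", "first", "only" and "open" are said of these compounds alone.

Of the compounds shown here, two sharing the same core have been measured. Compound 1 `CC(C)CC1(O)CCN(C(=O)Nc2cc(Oc3ccc(F)cc3)cc(Oc3ccc(CC(=O)O)cc3)c2)CC1` gives 21 nM in a functional assay on CHO cells for antagonist activity at sphingosine 1-phosphate receptor 2 (Homo sapiens), read by fluorescence; on this read-out lower numbers stand for stronger inhibition and higher numbers for weaker inhibition. Compound 2 `CC(C)CC1(O)CCN(C(=O)Nc2cc(Oc3ccc(C(=O)O)cc3)cc(Oc3ccc(F)c(F)c3)c2)CC1` gives 25 nM in this assay, a number that sits within the scatter of the one for compound 1, so no order between the two can be claimed; compound 1 merely has the lowest of the two numbers shown. Compound 2 also shows that a phenoxy ring bearing a carboxylic acid directly on the ring is compatible with this range of inhibition.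

Compound 3 `CC(C)CC1(O)CCN(C(=O)Nc2cc(Oc3ccc(F)cc3)cc(Oc3ccc(C(=O)O)cc3F)c2)CC1` has not yet been measured. It differs from compound 1 in one place: 4-carboxy-2-fluorophenyl in place of 4-(carboxymethyl)phenyl on an oxygen on an aromatic ring. The carboxylic acid thus moves onto the ring itself, and a fluorine is added to that ring.

Because compound 2 gives 25 nM with a carboxylic acid directly on the ring, the step from compound 1 to compound 3 is expected to stay within the scatter, a 1.2-fold higher number from compound 1 to compound 3 (0.08 log units; within the scatter). Compound 3 is therefore estimated at 25 nM, with a range from 8 nM to 80 nM.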

Compound 3, half-maximal inhibitory concentration: 17 nM
Compound 3: the middle estimate sits 1.5-fold (0.17 log units) above what was measured; low and high end bracket the measured number.
By their numbers in this assay, from the lowest: compounds 3, 1 and 2 (each within the scatter of the next).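

In this assay, placing 4-carboxy-2-fluorophenyl in place of 4-(carboxymethyl)phenyl on an oxygen on an aromatic ring gives a 1.2-fold lower number from compound 1 to compound 3 (0.09 log units; within the scatter), so the two numbers cannot be told apart. Compound 2 differs from compound 1 in more than one place, whereas compound 3 shows in a single step on the core of compound 1 that a carboxylic acid directly on this ring, together with a fluorine on the same ring, keeps the number within the scatter of the one for the 4-(carboxymethyl)phenyl group. Nothing available offers an explanation for this result.

Going by these compounds, this step joins two alterations, so it remains open what the carboxylic acid directly on the ring does without the fluorine, and what the fluorine does on a ring that keeps the carboxymethyl chain. Also open, on these data alone, is how this assay would respond at this place to a tetrazole or a primary amide instead of the carboxylic acid, or to a chlorine or a methyl group instead of the fluorine.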